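Adding fluoro: 3-bromophenyl to 3-bromo-4-fluorophenyl

This account rests on a few compounds, and the source may have more. Where it says the series, first, only, none or still open, it means among the compounds named here.

Compound 1 `O=C(Nc1cccc(Cl)c1)C1CCN(C/C=C/c2ccccc2)CC1`: 19100 nM
Compound 2 `O=C(Nc1cccc(Br)c1)C1CCN(C/C=C/c2ccccc2)CC1`: 16500 nM

Both values come from a functional assay on A549 cells (Homo sapiens) for inhibition, read by MTT assay, with a stated time of 72 h; a lower number here means a stronger inhibitor, a higher number a weaker inhibitor. Among the measured compounds shown here, compound 2 does not stand apart from compound 1, as the only measured step is a 1.2-fold lower number from compound 1 to compound 2 (0.06 log units; within the scatter). The next compound is compound 3 `O=C(Nc1ccc(F)c(Br)c1)C1CCN(C/C=C/c2ccccc2)CC1`, with fluoro in place of hydrogen on an aromatic carbon. This places fluoro in place of hydrogen on an aromatic carbon, ortho to the bromo group and para to a large group.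

For the measured compounds named here, the bromo-for-chloro step is the only measured evidence, and it was small. Going by the values given here, it is a swap of one halogen for another, however, and no measured step places a group on this carbon. The evidence is therefore thin, and no shift beyond the scatter is expected in this assay. The expected step is a 1.1-fold lower number from compound 2 to compound 3 (0.04 log units; within the scatter). Compound 3 is estimated at 15000 nM, with an expected range of 8000 nM to 28000 nM.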

Compound 3, half-maximal inhibitory concentration: 11700 nM
Compound 3: the middle estimate sits 1.3-fold (0.11 log units) above what was measured; the measured number falls inside the stated range.
By their numbers in this assay, from the lowest: compounds 3, 2 and 1 (each within the scatter of the next).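

Fluoro in place of hydrogen on this aromatic carbon, ortho to the bromo group and para to a large group, gives a 1.4-fold lower number from compound 2 to compound 3 (0.15 log units; within the scatter) in this assay, so this first substituent at the position does not separate from hydrogen. Even the combined change of 3-bromo-4-fluorophenyl in place of 3-chlorophenyl gives only a 1.6-fold lower number from compound 1 to compound 3 (0.21 log units; within the scatter) and thus leaves all three compounds at one level in this read-out. No accompanying measurement bears on this result.

From the compounds shown here alone, whether a methoxy group, a dimethylamino group or a carboxylic acid on this carbon would move the number beyond the scatter remains open. Also open, going by these compounds, is whether fluoro at this place would give the same result without the bromo group.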